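The source may report more compounds than this note shows. Statements on the series, on what has been measured and on what is new or still open speak of the compounds shown alone.

Of the compounds shown here, three built on one shared core have so far been tested in a functional assay on CCRF-CEM cells (Homo sapiens) for antiproliferative activity, with a stated time of 48 h; a lower number here means a stronger inhibitor of growth, a higher number a weaker inhibitor of growth. Compound 1 `Cc1cc(O)c(C2=NN(c3ccc(S(N)(=O)=O)cc3)C(c3ccccc3O)C2)cc1Cl` gives 100000 nM. Compound 2 `Cc1cc(O)c(C2=NN(c3ccc(S(N)(=O)=O)cc3)C(/C=C/c3ccccc3)C2)cc1Cl` gives 50000 nM. Compound 3 `COc1ccc(C2CC(c3cc(Cl)c(C)cc3O)=NN2c2ccc(S(N)(=O)=O)cc2)cc1OC` gives 100000 nM, level with compound 1 at the digits shown, and together these two carry the highest numbers of the three. Every step among the measured compounds stays within the scatter: a 2.0-fold lower number from compound 1 to compound 2 (0.30 log units; within the scatter), no change at the digits printed from compound 1 to compound 3 (within the scatter) and a 2.0-fold higher number from compound 2 to compound 3 (0.30 log units; within the scatter). Compound 4 `COc1ccc(C2CC(c3cc(Cl)c(C)cc3O)=NN2c2ccc(S(N)(=O)=O)cc2)c(OC)c1OC` has not yet been measured. It differs from compound 3 in one place: methoxy in place of hydrogen on an aromatic carbon. The two steps that led to compound 3 each exchanged the whole group on that saturated ring carbon without any shift beyond the scatter, and a smaller change to the same group is not expected to do more. In this assay compound 4 is therefore expected to give about 100000 nM, within 40000 nM to 200000 nM. The expected step is no change at the digits printed from compound 3 to compound 4 (within the scatter), nothing beyond the scatter.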

Compound 4, concentration for total growth inhibition: 100000 nM
Compound 4: middle estimate and measured number agree at the digits printed; the range from low to high includes it.
By their numbers in this assay, from the lowest: compounds 2, 1, 3 and 4 (each within the scatter of the next).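

Replacing hydrogen with methoxy on the aromatic ring, ortho to a large group and ortho to a methoxy group, alters only part of the group on the saturated ring carbon rather than exchanging all of it, and in this assay this gives no change at the digits printed from compound 3 to compound 4 (within the scatter). Against the other groups at that carbon, the 2,3,4-trimethoxyphenyl group gives a 2.0-fold higher number from compound 2 to compound 4 (0.30 log units; within the scatter) and no change at the digits printed from compound 1 to compound 4 (within the scatter), so none of the four groups shown there separates from the others beyond the scatter. Nothing measured here accounts for this flat result.

Still open, as far as these compounds go, is whether an amine or a carboxylic acid on that aromatic ring would move the number beyond the scatter. Also open, from the compounds shown here alone, is whether a change elsewhere on the shared core would do so.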